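Bromo to Chloro on a Shared Core: Expected Potency

The compounds below may be only part of what the source reports. "The series", "measured", "known", "first", "only" and "open" are said of these compounds alone.

Two compounds have been tested in a functional assay on cells (Melanoma cell, Homo sapiens) for cytotoxicity, read by sulforhodamine B assay, with a stated time of 48 h; on this read-out lower numbers stand for stronger inhibition of growth and higher numbers for weaker inhibition of growth:
Compound 1 `CN(C)c1ccc(C2CC(c3ccccc3)=NN2C2=NC(=O)/C(=C3\C(=O)Nc4ccccc43)S2)cc1` gives 6900 nM.
Compound 2 `CN(C)c1ccc(C2CC(c3ccccc3)=NN2C2=NC(=O)/C(=C3\C(=O)Nc4ccc(Br)cc43)S2)cc1` gives 200 nM.

For the measured compounds named here, compound 2 holds the lower of the two numbers; its only neighbour is compound 1, and a 35-fold lower number from compound 1 to compound 2 (1.54 log units; beyond the scatter). Compound 3 `CN(C)c1ccc(C2CC(c3ccccc3)=NN2C2=NC(=O)/C(=C3\C(=O)Nc4ccc(Cl)cc43)S2)cc1` differs from compound 2 by chloro in place of bromo on an aromatic carbon. Going by the values given here, no measured step exchanges one halogen for another; the only step touching this position is the large one from hydrogen to bromo. Since compound 2 gives 200 nM, compound 3 is expected to stay near it, perhaps slightly weaker. For compound 3 the expected step is a 1.8-fold higher number from compound 2 to compound 3 (0.24 log units; within the scatter). Compound 3 is estimated at 350 nM, between 120 nM and 1000 nM.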

Compound 3, concentration for 50% growth inhibition: 260 nM
Compound 3: middle estimate off by 1.3-fold (0.13 log units), on the high side; measured number inside the range.
By their numbers in this assay, from the lowest: compounds 2 and 3 (each within the scatter of the next); then compound 1.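

In this assay, chloro in place of bromo gives a 1.3-fold higher number from compound 2 to compound 3 (0.11 log units; within the scatter), which is within the scatter, so these two halogens cannot be told apart at this position. Chloro in place of hydrogen gives a 27-fold lower number from compound 1 to compound 3 (1.42 log units; beyond the scatter), a large step beyond the scatter, so the large drop first seen with bromo is not unique to bromo.

From the compounds shown here alone, whether fluoro, a methoxy group, an amine or a carboxylic acid on this carbon would give a similar number remains open. No available evidence explains why either halogen here goes with a lower number.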